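Changing the Aryl Group on the Amide Nitrogen

This account rests on a few compounds, and the source may have more. Where it says the series, first, only, none or still open, it means among the compounds named here.

Two measured compounds share one core and differ only in the aryl group attached to an amide-type nitrogen. In a functional assay on PC-3 cells (Homo sapiens) for inhibition, read by MTT assay, with a stated time of 72 h (a higher number here means a weaker inhibitor, a lower number a stronger inhibitor), compound 1 `COc1cccc(NC(=O)CSc2nc(Nc3ccccc3)c3ccccc3n2)c1` gives 11600 nM. In this assay compound 2 `O=C(CSc1nc(Nc2ccccc2)c2ccccc2n1)Nc1ccc(C(F)(F)F)cc1` gives 10400 nM. The step of a 1.1-fold lower number from compound 1 to compound 2 (0.05 log units; within the scatter) shows that these two numbers sit within the usual scatter of each other, so neither compound can be called the stronger or the weaker inhibitor on this evidence.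

Compound 3 `O=C(CSc1nc(Nc2ccccc2)c2ccccc2n1)Nc1ccc(F)c(Cl)c1` has not yet been measured. It differs from compound 2 in one place: 3-chloro-4-fluorophenyl in place of 4-(trifluoromethyl)phenyl on an amide-type nitrogen. For the measured compounds named here, the only measured step that bears on this kind of change is the exchange of one aryl group for another on the same nitrogen, a 1.1-fold lower number from compound 1 to compound 2 (0.05 log units; within the scatter), and that exchange left the number essentially where it was. With a single step of this type to go on, the expectation is that the change from compound 2 to compound 3 will again stay within the scatter, a 1.0-fold lower number from compound 2 to compound 3 (0.02 log units; within the scatter). The estimate for compound 3 in this assay is 10000 nM, with a range from 4000 nM to 25000 nM.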

Compound 3, half-maximal inhibitory concentration: 15500 nM
Estimate against measurement, compound 3: 1.6-fold (0.19 log units) below, and the stated range covers the measured number.
By their numbers in this assay, from the lowest: compounds 2, 1 and 3 (each within the scatter of the next).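

In this assay, putting 3-chloro-4-fluorophenyl on the amide-type nitrogen gives a 1.5-fold higher number from compound 2 to compound 3 (0.17 log units; within the scatter), and the comparison with the methoxy-bearing compound gives a 1.3-fold higher number from compound 1 to compound 3 (0.13 log units; within the scatter). For the compounds shown here, the first pair offered only a single exchange of aryl groups, whereas three different aryl groups can now be compared, and every pair among compounds 1, 2 and 3 lies within the usual scatter, so none can be called the stronger or the weaker inhibitor. For these three compounds, then, the choice among 3-methoxyphenyl, 4-(trifluoromethyl)phenyl and 3-chloro-4-fluorophenyl at this position does not separate the results, and nothing available here offers an explanation for that.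

As far as these compounds go, all three groups are substituted phenyl rings, so it remains open whether something of a different kind on this nitrogen, such as a ring carrying an amine or a carboxylic acid, or a longer carbon chain in place of the ring, would move the number beyond the scatter. The compounds shown also keep the rest of the shared core constant, so they cannot say how much a change elsewhere in the molecule would matter.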